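This account rests on a few compounds, and the source may have more. Where it says the series, first, only, none or still open, it means among the compounds named here.

Measured compounds:
Compound 1 `C=C(c1ccc(Cl)c(Cl)c1Cl)C1COC2(CCCC2)OO1` — in a functional assay on A549 cells (Homo sapiens) for inhibition, read by MTT assay, with a stated time of 72 h (a lower number here means a stronger inhibitor, a higher number a weaker inhibitor), compound 1 gives 690 nM.
Compound 2 `C=C(c1ccc(Cl)c(Cl)c1)C1COC2(CCCC2)OO1` — in this assay compound 2 gives 4680 nM.
Compound 3 `C=C(c1ccc(Cl)c(Cl)c1Cl)C1COC2(CCCCC2)OO1` — in this assay compound 3 gives 1370 nM.

The change from compound 1 to compound 2 is hydrogen in place of chloro on an aromatic carbon, and it gave a 6.8-fold higher number from compound 1 to compound 2 (0.83 log units; beyond the scatter). Compound 3 shares the aryl part of compound 1 but its core differs; the difference between the two cores is not broken down here. Compound 4 `C=C(c1ccc(Cl)cc1Cl)C1COC2(CCCCC2)OO1` is related to compound 3 by hydrogen in place of chloro on an aromatic carbon, the same kind of change as that from compound 1 to compound 2, but at a place ortho to two chloro groups and meta to a large group rather than ortho to a chloro group, ortho to a large group and meta to a chloro group. Resting on the earlier step of a 6.8-fold higher number from compound 1 to compound 2 (0.83 log units; beyond the scatter), the step from compound 3 to compound 4 is expected to be a 4.0-fold higher number from compound 3 to compound 4 (0.60 log units; beyond the scatter). Compound 4 is estimated at 5500 nM, between 2000 nM and 15000 nM.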

Compound 4, half-maximal inhibitory concentration: 810 nM
Compound 4: the middle estimate sits 6.8-fold (0.83 log units) above what was measured; the whole stated range lies above it.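

In this assay, hydrogen in place of chloro on an aromatic carbon gave a 1.7-fold lower number from compound 3 to compound 4 (0.23 log units; within the scatter), so the clear rise seen on the core of compound 1 did not carry over to the second core. The two steps do not agree: the same change on two cores in this assay, a 6.8-fold higher number (0.83 log units; beyond the scatter) from compound 1 to compound 2 and a 1.7-fold lower number (0.23 log units; within the scatter) from compound 3 to compound 4, 11-fold (1.06 log units) apart, beyond the scatter of two such steps. They differ both in the core and in the place of the chloro that leaves, and these compounds do not separate the two, so the result does not show which of them accounts for the gap.

The compounds shown leave open how the same removal at a single place behaves on both cores. They also leave open how a methoxy group or a nitrile would compare with chloro on this ring.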